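Replacing sec-butyl with (oxolan-2-yl)methyl on the shared core

This account rests on a few compounds, and the source may have more. Where it says the series, first, only, none or still open, it means among the compounds named here.

In a functional assay on K562 cells (Homo sapiens) for antiproliferative activity, read by CellTiter-Glo, with a stated time of 72 h (on this read-out higher numbers stand for an effect only at larger amounts of compound and lower numbers for an effect already at smaller amounts), compound 1 `CCCCCNc1ncnc2c1ncn2[C@@H]1O[C@H](COS(N)(=O)=O)[C@@H](O)[C@H]1O` gives 181 nM. Compound 2 `CCC(C)Nc1ncnc2c1ncn2[C@@H]1O[C@H](COS(N)(=O)=O)[C@@H](O)[C@H]1O` gives > 1000 nM, which is a limit of the assay and not a number. Compound 3 `NS(=O)(=O)OC[C@H]1O[C@@H](n2cnc3c(NCC4CCCO4)ncnc32)[C@H](O)[C@@H]1O` differs from compound 2 on a nitrogen on an aromatic ring: (oxolan-2-yl)methyl in place of sec-butyl on a nitrogen on an aromatic ring. Among the compounds with values here, the one measured step bearing on this is an at least 5.5-fold higher number from compound 1 to compound 2 (0.74 log units; beyond the scatter), which shows that the group at this place can matter. The expected change is an at least 1.4-fold lower number from compound 2 to compound 3 (0.15 log units; that floor lies within the scatter), a modest move to a lower number in this assay. Compound 3 is estimated at 700 nM, within an expected range of 200 nM to 2500 nM.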

Compound 3, half-maximal effective concentration: > 1000 nM
Compound 3: only a limit was reported; the forecaster's own chance of this, stated with the estimate: 35%; middle value at least 1.4-fold (0.15 log units) away from the limit.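

With (oxolan-2-yl)methyl on the nitrogen on an aromatic ring, this assay shows an at least 5.5-fold higher number from compound 1 to compound 3 (0.74 log units; beyond the scatter), so a second group besides sec-butyl falls short of pentyl at this place, this one carrying a five-membered ring and an oxygen. The result for compound 3 is, like that for compound 2, a limit of the assay and not a number, and the step between these two cannot be read: the limit of > 1000 nM in this assay, at which 2 of the 3 values shown sit.

As far as these compounds go, whether a longer straight chain such as hexyl, or a pentyl chain ending in an amine, would hold or change the value of compound 1 stays open. From the compounds shown here alone, how far compound 2 and compound 3 lie beyond their shared limit also stays open.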